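The source may hold more compounds than are shown below. What is called first, only, known or untested is meant among the compounds shown, and "the series" means these compounds.

Three compounds have been measured in an assay on S100 cells for inhibition of Polyunsaturated fatty acid 5-lipoxygenase (Homo sapiens), read by HPLC, with stated times of 15 min and 10 min; a higher number here means a weaker inhibitor, a lower number a stronger inhibitor:

compound 1, `Clc1ccc2nc(-c3ccc(N4CCCCC4)cc3)c(NC3CCCCC3)n2c1`, 60 nM
compound 2, `Cc1ccc2nc(-c3ccccc3O)c(NC3CCCCC3)n2c1`, 1800 nM
compound 3, `Oc1ccc(-c2nc3ccc(Br)cn3c2NC2CCCCC2)cc1`, 900 nM

Compound 2 gives the highest of these three numbers, yet its gap to compound 3 is within the usual scatter, so those two cannot be told apart; compound 1, by contrast, sits clearly below compound 2, well beyond the scatter.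

The unmeasured compound 4, `COc1ccc(-c2nc3ccc(C)cn3c2NC2CCCCC2)cc1`, keeps the core of compound 2 and differs from it in a single place: 4-methoxyphenyl in place of 2-hydroxyphenyl on an aromatic carbon. Among the measured compounds shown here, no pair of measured compounds tracks exactly this change, so the direction can only be read loosely from the three numbers. The two compounds that carry a group at the 4-position of the phenyl ring, compound 3 with a hydroxy and compound 1 with a piperidine, are the two that give the lower numbers, and compound 1 does so decisively.

A moderate drop in the number is therefore expected. The estimated step of a 4.5-fold lower number from compound 2 to compound 4 (0.65 log units; beyond the scatter) should exceed the scatter without approaching the number of compound 1. Compound 4 is expected to give 400 nM in this assay, with a likely range from 120 nM to 1300 nM.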

Compound 4, half-maximal inhibitory concentration: 500 nM
Beside the measured number, compound 4's estimate is 1.3-fold (0.10 log units) below it, and the stated range covers the measured number.
By their numbers in this assay, from the lowest: compound 1; then compounds 4, 3 and 2 (each within the scatter of the next, the first and the last beyond it).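

Swapping 2-hydroxyphenyl for 4-methoxyphenyl on this aromatic carbon, next to the ring atom that bears the cyclohexylamino group, gives in this assay a 3.6-fold lower number from compound 2 to compound 4 (0.56 log units; beyond the scatter), a modest step but one beyond the scatter. Among the compounds shown here, this is the first comparison here in which only one place changes, so the rest of the molecule can be set aside when reading it, and it shows that this position responds to what the phenyl ring carries and that a hydrogen-bond donor on that ring is not needed for the lower number. Nothing given here accounts for the size or direction of this step.

For the compounds shown here, the single step also bundles two changes, the place of the oxygen on the phenyl ring and hydroxy versus methoxy, and a 2-methoxyphenyl or 4-hydroxyphenyl group on the core of compound 2 would be needed to pull them apart. From the compounds shown here alone, it also remains open whether a larger group at the 4-position of the phenyl ring, such as the piperidine of compound 1 or a simple amine, would lower the number further on this same core.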